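Changing the group on one nitrogen of compound 2

The source may report more compounds than this note shows. Statements on the series, on what has been measured and on what is new or still open speak of the compounds shown alone.

Among the measured compounds shown here, in a functional assay on HUVEC cells (Homo sapiens) for inhibition (a higher number here means a weaker inhibitor, a lower number a stronger inhibitor), compound 2 `CN(c1ccc(N/C(S)=N/c2ccccc2)cc1)c1ccnc(Nc2cccc(CS(C)(=O)=O)c2)n1` gives 6 nM as its half-maximal inhibitory concentration, the middle of the three numbers measured so far. Compound 1 `CN(c1ccc(NC(=O)Oc2ccccc2)cc1)c1ccnc(Nc2cccc(CS(C)(=O)=O)c2)n1` stands higher at 224 nM on this scale. Compound 3 `CN(c1ccc(NC(=O)Nc2ccccc2)cc1)c1ccnc(Nc2cccc(S(N)(=O)=O)c2)n1` stands lower at 2 nM on the same scale.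

The unmeasured compound 4 `CC(=O)c1ccc(NC(=O)Nc2ccc(N(C)c3ccnc(Nc4cccc(CS(C)(=O)=O)c4)n3)cc2)cc1` differs from compound 2 in one place: a group of 12 heavy atoms (9 carbon, 1 nitrogen, 2 oxygen; one six-membered aromatic ring of carbon only) in place of a group of 9 heavy atoms (7 carbon, 1 nitrogen, 1 sulfur; one six-membered aromatic ring of carbon only), on a nitrogen on an aromatic ring and the rest of the structure stays the same. The incoming group is named (4-acetylphenyl)carbamoyl.

For the measured compounds named here, only one measured step involves a swap at this nitrogen alone. That step, a 37-fold lower number from compound 1 to compound 2 (1.57 log units; beyond the scatter) in size, is large and shows that the group here can matter a great deal. It involves different groups, however, so it gives no direction for the new change. Compound 3 at 2 nM also has a carbamoyl group on this nitrogen and still gives a low number, although it differs from compound 4 elsewhere too.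

The expected step is no change at the digits printed from compound 2 to compound 4 (within the scatter) and this estimate means no shift beyond the scatter in this assay in either direction. For compound 4 the estimated value is 6 nM with an expected range from 1.5 nM to 30 nM in this measurement.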

Compound 4, half-maximal inhibitory concentration: 2 nM
The estimate for compound 4 lay 3.0-fold (0.48 log units) above the measured number; the measured number falls inside the stated range.
By their numbers in this assay, from the lowest: compounds 3 and 4 (each within the scatter of the next); then compound 2; then compound 1.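

In this assay, the nitrogen on the aromatic ring accepts (4-acetylphenyl)carbamoyl, a group with more heavy atoms than the sulfur-containing group it replaces, and the number falls rather than rises: a 3.0-fold lower number from compound 2 to compound 4 (0.48 log units; beyond the scatter). The earlier compounds shown here showed only that this position could matter, whereas this step shows that a larger group carrying an acetyl can be placed here without losing activity in this assay. The second new step concerns the atoms on the carbonyl carbon, where (4-acetylphenyl)amino in place of phenoxy gives a 110-fold lower number from compound 1 to compound 4 (2.05 log units; beyond the scatter), so a change at this carbonyl carbon that also adds the acetyl can move the number by far more than the step from the sulfur-containing group; no measurement offered here explains why either step occurs.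

Each step changes the link to the ring and adds the acetyl at once, so the share of each remains open, and a plain phenylcarbamoyl group on the core of compound 4 is absent from the compounds shown. As far as these compounds go, whether a carboxylic acid or a methoxy group in place of the acetyl would give a similar number also remains open.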